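Cytotoxicity notes: cyclohexyl in place of 4-aminophenyl

The compounds below may be only part of what the source reports. "The series", "measured", "known", "first", "only" and "open" are said of these compounds alone.

Compound 1 `COc1ccccc1C(=O)c1ccn(-c2ccc3c(c2)B(O)OC3)c1`: in an ADME assay on L929 cells (Mus musculus) for cytotoxicity, read by resazurin assay, with a stated time of 72 h (on this read-out lower numbers stand for stronger inhibition and higher numbers for weaker inhibition), compound 1 gives > 10 ug/mL, which is a limit of the assay.
Compound 2 `NCc1ccc(C(=O)c2ccn(-c3ccc4c(c3)B(O)OC4)c2)cc1`: in this assay compound 2 gives > 10 ug/mL, again a limit of the assay.
Compound 3 `Nc1ccc(C(=O)c2ccn(-c3ccc4c(c3)B(O)OC4)c2)cc1`: in this assay compound 3 gives 3.9 ug/mL.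

Within the data shown here, compound 3 is thus the only member with a number; the other two sit at the limit (the limit of > 10 ug/mL in this assay, at which 2 of the 3 values shown sit). Compound 4 `O=C(c1ccn(-c2ccc3c(c2)B(O)OC3)c1)C1CCCCC1` differs from compound 3 in one place: cyclohexyl in place of 4-aminophenyl on a carbonyl carbon. Among the measured compounds shown here, two measured steps bear on this position. There is an at least 2.5-fold lower number from compound 1 to compound 3 (0.40 log units; beyond the scatter) and an at least 2.5-fold lower number from compound 2 to compound 3 (0.40 log units; beyond the scatter), so whenever the group on the carbonyl carbon was something other than 4-aminophenyl the value stayed at the limit. Removing 4-aminophenyl in compound 4 is therefore expected to raise the number again, an expected 2.3-fold higher number from compound 3 to compound 4 (0.36 log units; beyond the scatter) in this assay, with a fair chance that only a limit is returned. The estimate for compound 4 is 9 ug/mL, within 3.5 ug/mL to 25 ug/mL.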

Compound 4, half-maximal inhibitory concentration: > 10 ug/mL
Compound 4 gave a limit, no number; the forecaster's own chance of this, stated with the estimate: 50%; middle value at least 1.1-fold (0.04 log units) from the limit.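

In this assay there is an at least 2.5-fold higher number from compound 3 to compound 4 (0.40 log units; beyond the scatter), so the loss of 4-aminophenyl is now seen with a non-aromatic carbon ring on the carbonyl carbon as well as with the two substituted phenyl groups of compound 1 and compound 2. Among the four groups shown, only 4-aminophenyl gives a number, and the other three groups all end at the same limit: the limit of > 10 ug/mL in this assay, at which 3 of the 4 values shown sit. The steps from compound 1 and from compound 2 to compound 4 cannot be read, as both ends of each are limits, so these three groups cannot be ranked.

The compounds shown leave open whether the ring or the amine matters more in 4-aminophenyl. An unsubstituted phenyl and a 4-aminocyclohexyl group on the carbonyl carbon would separate the two.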